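This account rests on a few compounds, and the source may have more. Where it says the series, first, only, none or still open, it means among the compounds named here.

Compound 1 `CC1=C(N2CC2)C(=O)C(CC(C)OC(N)=O)=C(N2CC2)C1=O` gives the strongest number in a functional assay on L1210 cells (Mus musculus), with a stated time of 12 days (on this read-out higher numbers stand for higher potency (the scale is a negative logarithm) and lower numbers for lower potency), among the three compounds measured: in this assay compound 1 gives 5.79. Compound 2 `CCC(OC)C1=C(N2CC2)C(=O)C(C)=C(N2CC2)C1=O` gives 5.33 in this assay, and compound 3 `CC1=C(N2CC2)C(=O)C(C2CCCCC2)=C(N2CC2)C1=O` gives 5.39. The two changes away from compound 1 both cost potency: a number 0.46 log units lower from compound 1 to compound 2 (beyond the scatter), and a number 0.40 log units lower from compound 1 to compound 3 (beyond the scatter). Between the two lower compounds the difference is small, a number 0.06 log units higher from compound 2 to compound 3 (within the scatter).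

Compound 4 `CC1=C(N2CC2)C(=O)C(COc2ccccc2)=C(N2CC2)C1=O` is now considered. Relative to compound 1 the change is a group of 7 heavy atoms (6 carbon, 1 oxygen; one six-membered aromatic ring of carbon only) in place of a group of 6 heavy atoms (3 carbon, 1 nitrogen, 2 oxygen; no ring), on a saturated chain carbon bound to a double-bonded ring carbon. The two measured steps that bear on this are those from compound 1 to compound 2 and from compound 1 to compound 3, in which the side chain that holds nitrogen and two oxygen atoms is exchanged for a group without nitrogen, and each time the number fell modestly, a number 0.46 log units lower from compound 1 to compound 2 (beyond the scatter) and a number 0.40 log units lower from compound 1 to compound 3 (beyond the scatter). Compound 4 likewise gives up the nitrogen-bearing part of that chain, keeping one oxygen within a phenoxy group, so the expectation for compound 4 is a modest step down in this assay, a number 0.39 log units lower from compound 1 to compound 4 (beyond the scatter). Compound 4 is therefore expected to give about 5.4 in this assay, with a range from 4.9 to 5.9.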

Compound 4, logarithm of the reciprocal of the active concentration, log(1/C): 4.71
Compound 4: middle estimate off by 0.69 log units, on the high side; the measured number lies below the stated range.
By their numbers in this assay, from the lowest: compound 4; then compounds 2 and 3 (each within the scatter of the next); then compound 1.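

In this assay the replacement of the carbamate-bearing group by phenoxy, on a saturated chain carbon bound to a double-bonded ring carbon, is a large step, a number 1.08 log units lower from compound 1 to compound 4 (beyond the scatter), and it exceeds the two modest steps, a number 0.46 log units lower from compound 1 to compound 2 (beyond the scatter) and a number 0.40 log units lower from compound 1 to compound 3 (beyond the scatter). Keeping that saturated chain carbon in compound 4 therefore does not hold the number up, and the earlier steps show that losing the nitrogen-bearing group need not cost this much, since compound 2 and compound 3 also lack it. Compound 4 also differs from those two in carrying a six-membered aromatic ring, the only one among the compounds shown, but a single compound cannot tie the larger loss to that ring. Nothing measured here accounts for the size of this step.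

From the compounds shown here alone, what a cyclohexyloxy or a methoxy group would give on the same saturated chain carbon remains open, and with it whether the larger loss goes with the aromatic ring or with some other feature of phenoxy. Also open, going by these compounds, is how a primary amine or a hydroxyl group at that carbon would compare with the carbamate-bearing group of compound 1.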